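Urea to amide on a shared pyrazole-derived scaffold

The compounds below may be only part of what the source reports. "The series", "measured", "known", "first", "only" and "open" are said of these compounds alone.

Of the compounds shown here, three share one core and have been tested in a functional assay on ACHN cells (Homo sapiens) for inhibition, read by sulforhodamine B assay, with a stated time of 48 h, tested at 10 uM; a higher number here means a weaker effect of the compound at the concentration tested, a lower number a stronger effect. Compound 1 `O=C(Nc1cccc(-n2cc(-c3ccncc3)c(-c3cc(O)cc(Cl)c3)n2)c1)Nc1ccc(Cl)c(C(F)(F)F)c1` gives 21.3% there. Compound 2 `COc1cc(Cl)cc(-c2nn(-c3cccc(NC(=O)Nc4ccc(Cl)c(C(F)(F)F)c4)c3)cc2-c2ccncc2)c1` carries a methyl in place of hydrogen on an oxygen on an aromatic ring, and the step of a number 12.5 percentage points lower from compound 1 to compound 2 (beyond the scatter) is the only one beyond the scatter among the three. Compound 3 `COc1cc(Cl)cc(-c2nn(-c3cccc(NC(=O)Nc4cc(C(F)(F)F)cc(C(F)(F)F)c4)c3)cc2-c2ccncc2)c1` gives 10.3% in this assay. Compound 2 itself gives 8.78%, the lowest of the three numbers; its nearest neighbour is compound 3, within the scatter, and the furthest is compound 1.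

Compound 4 `COc1cc(Cl)cc(-c2nn(-c3cccc(NC(=O)c4cccc(C(F)(F)F)c4)c3)cc2-c2ccncc2)c1` differs from compound 2 as follows: 3-(trifluoromethyl)phenyl in place of (4-chloro-3-(trifluoromethyl)phenyl)amino on a carbonyl carbon. Within the data shown here, no measured step touches this kind of change. Among the measured compounds shown here, the values of compound 2 and compound 3 show only that two different aryl groups on the far side of the urea give numbers within the scatter of each other; the removal of the urea nitrogen with its hydrogen-bond donor is untested. For this reason the expectation is uncertain, and a step toward a higher number, that is a weaker effect, is expected for compound 4, a number 21.2 percentage points higher from compound 2 to compound 4 (beyond the scatter). Compound 4 is therefore estimated at 30%, within a range from 5% to 70%.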

Compound 4, a percentage reported as activity, at one concentration (the size of the read-out at that concentration, not a potency): 48.1%
Beside the measured number, compound 4's estimate is 18.1 percentage points below it, within the range that was stated.
By their numbers in this assay, from the lowest: compounds 2 and 3 (each within the scatter of the next); then compound 1; then compound 4.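

Up to now, the only comparison on this side of the carbonyl was between compound 2 and compound 3, whose two aryl ureas stayed within the scatter of each other. The amide of compound 4 shows that the position is not indifferent to every change: in this assay, 3-(trifluoromethyl)phenyl in place of (4-chloro-3-(trifluoromethyl)phenyl)amino on a carbonyl carbon gives a number 39.3 percentage points higher from compound 2 to compound 4 (beyond the scatter), a large loss of effect at the concentration tested. Nothing at hand bears on why this change weakens the effect.

The change removes the amino nitrogen with its hydrogen and the chlorine together, so the compounds shown leave open which of the two accounts for the step; (3-(trifluoromethyl)phenyl)amino or 4-chloro-3-(trifluoromethyl)phenyl on the same carbonyl carbon would separate them. Also open, going by these compounds, is whether another link in place of the amino nitrogen, such as a methylene or an oxygen as in a carbamate, would keep the effect seen with the urea of compound 2.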